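Ethynyl in place of ethyl on compound 3

This account rests on a few compounds, and the source may have more. Where it says the series, first, only, none or still open, it means among the compounds named here.

In a functional assay on HCT-116 cells (Homo sapiens) for antiproliferative activity, read by radiometric assay, with a stated time of 72 h (on this read-out higher numbers stand for weaker inhibition and lower numbers for stronger inhibition), compound 1 `Cc1ccccc1Nc1ncnc2cc(NC(=O)CCCCCCC(=O)NO)sc12` gives 2560 nM, compound 2 `Cc1cc(F)ccc1Nc1ncnc2cc(NC(=O)CCCCCCC(=O)NO)sc12` gives 2640 nM and compound 3 `CCc1cccc(Nc2ncnc3cc(NC(=O)CCCCCCC(=O)NO)sc23)c1` gives 1440 nM. Compound 3 thus stands level with the other two, since a 1.8-fold lower number from compound 1 to compound 3 (0.25 log units; within the scatter) and a 1.8-fold lower number from compound 2 to compound 3 (0.26 log units; within the scatter) are both small. The remaining step, a 1.0-fold higher number from compound 1 to compound 2 (0.01 log units; within the scatter), is no larger. Compound 4 `C#Cc1cccc(Nc2ncnc3cc(NC(=O)CCCCCCC(=O)NO)sc23)c1` carries ethynyl in place of ethyl on an aromatic carbon, (ethynyl in place of ethyl on an aromatic carbon). Among the compounds with values here, no measured step makes this exact change, but all three steps on this group or its ring stayed within the scatter. No step beyond the scatter is therefore expected in this assay, and the estimated step is a 1.0-fold higher number from compound 3 to compound 4 (0.02 log units; within the scatter). For compound 4 the expected value is 1500 nM, within an estimated range of 600 nM to 3600 nM.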

Compound 4, half-maximal inhibitory concentration: 1010 nM
Estimate against measurement, compound 4: 1.5-fold (0.17 log units) above, within the range that was stated.
By their numbers in this assay, from the lowest: compounds 4, 3, 1 and 2 (each within the scatter of the next, the first and the last beyond it).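

In this assay, ethynyl on this carbon, meta to a large group, stays level with ethyl, with a 1.4-fold lower number from compound 3 to compound 4 (0.15 log units; within the scatter) inside the scatter. Within the data shown here, the change does give the first steps in this set beyond the scatter, though both are modest: a 2.6-fold lower number from compound 2 to compound 4 (0.42 log units; beyond the scatter) and a 2.5-fold lower number from compound 1 to compound 4 (0.40 log units; beyond the scatter). Compound 3 had reached neither margin against those same two compounds, so 3-ethynylphenyl separates from 2-methylphenyl and 4-fluoro-2-methylphenyl where 3-ethylphenyl did not. On these data alone, whether a nitrile or a methoxy group on this carbon would give a number in the same range remains open. No evidence is available that explains these steps.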